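Changing the Aryl Group on a Ring Nitrogen: Compound 3

This account rests on a few compounds, and the source may have more. Where it says the series, first, only, none or still open, it means among the compounds named here.

Measured so far:
compound 1, `N#CC1=C(N)Oc2c(c3nc4ccccc4nc3c3ccccc23)C12C(=O)N(Cc1cnnn1-c1ccc(S(N)(=O)=O)cc1)c1ccccc12`: 31200 nM
compound 2, `N#CC1=C(N)Oc2c(N)cc3nc4ccccc4nc3c2C12C(=O)N(Cc1cnnn1-c1ccc(Cl)cc1)c1ccccc12`: > 50000 nM

Compound 1 gives 31200 nM in a functional assay on HCT-116 cells (Homo sapiens) for antiproliferative activity, read by MTT assay, with a stated time of 48 h; on this read-out lower numbers stand for stronger inhibition and higher numbers for weaker inhibition. For compound 2 only a limit is reported in this assay, > 50000 nM; this is the limit of > 50000 nM in this assay, at which 1 of the 2 values shown sits. Compound 3, `Cc1ccc(C)c(-n2nncc2CN2C(=O)C3(C(C#N)=C(N)Oc4c(N)cc5nc6ccccc6nc5c43)c3ccccc32)c1`, differs from compound 2 by 2,5-dimethylphenyl in place of 4-chlorophenyl on an aromatic nitrogen. Going by the values given here, no step between measured compounds is available, so the size of this change cannot be read from the data. Compound 2 sits at the limit, and only a gain beyond the scatter could register. Compound 3 is expected to remain weak, at an estimated 45000 nM, between 15000 nM and 100000 nM. The step of an at least 1.1-fold lower number from compound 2 to compound 3 (0.04 log units; that floor lies within the scatter) is expected to stay within the scatter.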

Compound 3, half-maximal inhibitory concentration: > 50000 nM
Compound 3: a limit, no number; the forecaster's own chance of this, stated with the estimate: 60%; at least 1.1-fold (0.04 log units) between middle value and limit.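

No step from compound 2 to compound 3 can be read, because both are reported only as limits: the limit of > 50000 nM in this assay, at which 2 of the 3 values shown sit.

The compounds shown leave open whether 2,5-dimethylphenyl and 4-chlorophenyl on that aromatic nitrogen differ at all in this assay.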